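Ring substituent swap on the aromatic nitrogen of compound 1

The source may report more compounds than this note shows. Statements on the series, on what has been measured and on what is new or still open speak of the compounds shown alone.

Compound 1 `CCNC(=O)c1cc(Oc2ccc(NC(=O)c3nn(-c4ccccc4C)c(=O)cc3C)cc2)ccn1` is assessed in a functional assay on HeLa cells (Homo sapiens) for antiproliferative activity, read by MTT assay, with a stated time of 72 h (a higher number here means a weaker inhibitor, a lower number a stronger inhibitor), where compound 1 gives 27300 nM, the highest of the three numbers recorded. Compound 2 `CCCNC(=O)c1cc(Oc2ccc(NC(=O)c3nn(-c4ccc(C)cc4)c(=O)cc3C)cc2F)ccn1` sits nearest: in this assay compound 2 gives 14200 nM, within the scatter of compound 1. Compound 3 `CCCNC(=O)c1cc(Oc2ccc(NC(=O)c3nn(-c4ccccc4OC(F)(F)F)c(=O)cc3C)cc2F)ccn1` lies furthest off: in this assay compound 3 gives 3690 nM, a gap from compound 1 that is beyond the scatter.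

Compound 4 `CCNC(=O)c1cc(Oc2ccc(NC(=O)c3nn(-c4cccc(C(F)(F)F)c4)c(=O)cc3C)cc2)ccn1` has not yet been measured. It differs from compound 1 in one place: 3-(trifluoromethyl)phenyl in place of 2-methylphenyl on an aromatic nitrogen.

Within the data shown here, the only measured step that bears on this change is the one from compound 2 to compound 3, where a methylphenyl on the same aromatic nitrogen gave way to a fluorinated phenyl; that step gave a 3.8-fold lower number from compound 2 to compound 3 (0.59 log units; beyond the scatter). The change into compound 4 is of the same kind, though the shared core around it matches compound 1 rather than compound 2 or compound 3, so a step of similar modest size, toward a lower number, is expected but with wide uncertainty.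

The step from compound 1 to compound 4 is therefore estimated at a 3.0-fold lower number from compound 1 to compound 4 (0.48 log units; beyond the scatter). Compound 4 is expected to give 9000 nM in this assay, with a range from 3000 nM to 27000 nM.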

Compound 4, half-maximal inhibitory concentration: 10700 nM
For compound 4 the middle estimate is 1.2-fold (0.08 log units) below the measured one; the measured number falls inside the stated range.
By their numbers in this assay, from the lowest: compound 3; then compounds 4, 2 and 1 (each within the scatter of the next, the first and the last beyond it).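

On the core of compound 1, the change to 3-(trifluoromethyl)phenyl on the aromatic nitrogen gives a 2.6-fold lower number from compound 1 to compound 4 (0.41 log units; beyond the scatter) in this assay. The earlier step on this nitrogen was read only on the core of compound 2 and compound 3, so a fluorinated phenyl in place of a methylphenyl has now given a lower number on two cores, and neither listed step goes against this. No evidence on the cause of the step is available.

On these data alone, the methyl group gives way to trifluoromethyl and the substituent's place on the phenyl ring changes in the same step, so the contribution of each remains open. Also open, as far as these compounds go, is how this nitrogen's phenyl ring would respond to a carboxylic acid or an amine on it.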